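Isopropyl for methylsulfanyl on a potent five-HT7 ligand

A few compounds are considered here, and "the series" means these few. Any claim that something is new, unique, unknown or untested is made for them only; others in the source may bear on it.

Compound 1 `CC(C)c1ccccc1N1CCN(CCCCCC(=O)NCc2ccncc2)CC1` and compound 2 `CSc1ccccc1N1CCN(CCCCCC(=O)NCc2ccc(C#N)cc2)CC1` share a long chain linking an arylpiperazine to an amide. In an assay on HEK293 cells for displacement of a labelled ligand from 5-hydroxytryptamine receptor 7 (Rattus norvegicus) (on this read-out higher numbers stand for weaker inhibition and lower numbers for stronger inhibition), compound 1 gives 5.1 nM, and in this assay compound 2 gives 9 nM, a gap within the usual scatter, so neither can be called the stronger. Compound 3 `CC(C)c1ccccc1N1CCN(CCCCCC(=O)NCc2ccc(C#N)cc2)CC1` carries the change (isopropyl in place of methylsulfanyl on an aromatic carbon). Within the data shown here, no such step is known here, yet compound 1 shows the isopropyl group with a low number at 5.1 nM, so the step from compound 2 is expected to stay within the scatter, a 1.5-fold lower number from compound 2 to compound 3 (0.18 log units; within the scatter). Compound 3 is therefore estimated at 6 nM, between 2 nM and 20 nM.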

Compound 3, inhibition constant: 8.6 nM
For compound 3 the middle estimate is 1.4-fold (0.16 log units) below the measured one; measured number inside the range.
By their numbers in this assay, from the lowest: compounds 1, 3 and 2 (each within the scatter of the next).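

Isopropyl in place of methylsulfanyl, on an aromatic carbon ortho to a large group, gives a 1.0-fold lower number from compound 2 to compound 3 (0.02 log units; within the scatter) in this assay, so with the rest of the structure held fixed, these two groups cannot be told apart at this position. With the 2-isopropylphenyl group held fixed, 4-cyanophenyl in place of pyridin-4-yl gives a 1.7-fold higher number from compound 1 to compound 3 (0.23 log units; within the scatter), so that change also shows no readable difference. No measurement shown here explains why these groups read alike. On these data alone, whether a methoxy or amino group on this aromatic carbon would read differently remains open, as does the effect of a shorter chain.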